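A few compounds are considered here, and "the series" means these few. Any claim that something is new, unique, unknown or untested is made for them only; others in the source may bear on it.

Series notes. In a functional assay on HCT-116 cells (Homo sapiens) for inhibition, read by sulforhodamine B assay, with a stated time of 48 h, tested at 50 uM (on this read-out higher numbers stand for more inhibition of growth at the one concentration tested and lower numbers for less inhibition of growth), compound 1 `O=C1C(=O)N(CCCCCn2cc(COc3cc(=O)oc4ccccc34)nn2)c2ccc(F)cc21` gives 59% and compound 2 `O=C1C(=O)N(CCCCCn2cc(COc3cc(=O)oc4ccccc34)nn2)c2ccc(I)cc21` gives 36%. Within the data shown here, the one change between them, (fluoro in place of iodo on an aromatic carbon), produced a number 23 percentage points higher from compound 2 to compound 1 (beyond the scatter). Compound 3 `O=C1C(=O)N(CCCn2cc(COc3cc(=O)oc4ccccc34)nn2)c2ccc(I)cc21` differs from compound 2 in a way not broken down here; in this assay compound 3 gives 65%, and this value and that of compound 1 lie within the scatter of each other. Compound 4 `O=C1C(=O)N(CCCn2cc(COc3cc(=O)oc4ccccc34)nn2)c2ccc(F)cc21` carries the same change relative to compound 3, (fluoro in place of iodo on an aromatic carbon), at the same place. Because compound 3 already stands at 65%, less room remains upward on this read-out. The expected step is therefore a number 15 percentage points higher from compound 3 to compound 4 (beyond the scatter), beside the earlier one. Compound 4 is estimated at 80%, between 65% and 95%.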

Compound 4, percent growth inhibition at one concentration: 75%
Compound 4: middle estimate off by 5 percentage points, on the high side; low and high end bracket the measured number.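

In this assay, fluoro in place of iodo on an aromatic carbon gives a number 10 percentage points higher from compound 3 to compound 4 (within the scatter), so this step alone does not separate the two compounds. Set beside the earlier step, it points the same way and does not differ in size: the same change on two cores in this assay, a number 23 percentage points higher (beyond the scatter) from compound 2 to compound 1 and a number 10 percentage points higher (within the scatter) from compound 3 to compound 4, 13 percentage points apart, within the scatter of two such steps This supports carrying the change from one core to the other in direction only, with just two pairs behind it, and it neither shows a gain of its own on the core of compound 3 nor rules out a real difference in size on the two cores.

Still open, on these data alone, is how chloro or bromo at this aromatic carbon would compare with fluoro and iodo. Also open, as far as these compounds go, is whether the same change holds with a longer chain than that of compound 1.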